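A Sulfur-Bearing Tail Replaces the Fluorinated Carbamate Ester

This account rests on a few compounds, and the source may have more. Where it says the series, first, only, none or still open, it means among the compounds named here.

Three compounds share one core and differ only in the group attached through oxygen to the carbonyl of the ring-bound carbamate. Compound 1 `Cc1nc(S(C)(=O)=O)ccc1Oc1ncnc(OC2CCN(C(=O)O[C@@H](C)CF)CC2)c1F` carries a 1-(fluoromethyl)ethyl group there, and in a functional assay on isolated protein for inhibition of Glucose-dependent insulinotropic receptor (Rattus norvegicus), read by HTRF and cAMP accumulation (on this read-out lower numbers stand for an effect already at smaller amounts and higher numbers for an effect only at larger amounts of compound), compound 1 gives 1680 nM, the highest of the three numbers. Compound 2 `CCC1(OC(=O)N2CCC(Oc3ncnc(Oc4ccc(S(C)(=O)=O)nc4C)c3F)CC2)CC1` carries 1-ethylcyclopropyl instead and gives 333 nM; compound 3 `Cc1nc(S(C)(=O)=O)ccc1Oc1ncnc(OC2CCN(C(=O)OC3(C(F)(F)F)CCC3)CC2)c1F` carries 1-(trifluoromethyl)cyclobutyl and gives 63.3 nM. Both exchanges lowered the number: a 5.0-fold lower number from compound 1 to compound 2 (0.70 log units; beyond the scatter), and a 27-fold lower number from compound 1 to compound 3 (1.42 log units; beyond the scatter), while a 5.3-fold lower number from compound 2 to compound 3 (0.72 log units; beyond the scatter).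

Compound 4 `Cc1nc(S(C)(=O)=O)ccc1Oc1ncnc(OC2CCN(C(=O)SC(C)(C)C)CC2)c1F` takes a different route. Here the change is a group of 5 heavy atoms (4 carbon, 1 sulfur; no ring) in place of a group of 5 heavy atoms (3 carbon, 1 oxygen, 1 fluorine; no ring), on a carbonyl carbon, so the oxygen itself leaves together with its fluorinated branch, and a (tert-butyl)sulfanyl group enters on the carbonyl carbon. Among the measured compounds shown here, no measured step swaps the oxygen for sulfur; the two steps from compound 1 only bear on it indirectly, in that every replacement of the 1-(fluoromethyl)ethyl group seen so far gave a lower number, by modest to large amounts.

On that footing the step is expected to be a 2.8-fold lower number from compound 1 to compound 4 (0.45 log units; beyond the scatter), a modest lowering beyond the scatter but with wide uncertainty. Compound 4 is therefore estimated at 600 nM in this assay, within a range from 150 nM to 2500 nM.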

Compound 4, half-maximal effective concentration: 30.7 nM
Compound 4: the middle estimate sits 20-fold (1.29 log units) above what was measured, outside the stated range (below it).
By their numbers in this assay, from the lowest: compound 4; then compound 3; then compound 2; then compound 1.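

The position on the carbonyl carbon tolerates more than a new branch on the oxygen: (tert-butyl)sulfanyl brings sulfur to the carbonyl carbon, and in this assay this exchange gives the largest step seen here, a 55-fold lower number from compound 1 to compound 4 (1.74 log units; beyond the scatter) in all. The group also goes beyond both earlier replacements, with an 11-fold lower number from compound 2 to compound 4 (1.04 log units; beyond the scatter) and a 2.1-fold lower number from compound 3 to compound 4 (0.31 log units; beyond the scatter) as the two steps, so among these four compounds the lowest number belongs to a group with no ring and no fluorine, while compound 2 and compound 3 each carry a ring and compound 3 also carries fluorine. Among the compounds shown here, no measurement at hand explains why this exchange lowers the number so far.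

The sulfur and the tert-butyl branch enter together. No compound shown pairs that same branch with oxygen, and the data shown do not separate the two. Going by these compounds, it also remains open whether a smaller group on sulfur, such as methylsulfanyl, or an amine on the carbonyl carbon would keep a number this low.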